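Moving the halogen on the pendant phenyl ring

A few compounds are considered here, and "the series" means these few. Any claim that something is new, unique, unknown or untested is made for them only; others in the source may bear on it.

Measured so far:
compound 1 `O=c1c2ccccc2[se]n1-c1nnc(-c2ccccc2Br)s1`: 59400 nM
compound 2 `O=c1c2ccccc2[se]n1-c1nnc(-c2ccccc2[N+](=O)[O-])s1`: 31200 nM
compound 3 `COc1ccccc1-c1nnc(-n2[se]c3ccccc3c2=O)s1`: 3920 nM

In a functional assay on MCF7 cells (Homo sapiens) for antiproliferative activity, read by CCK-8 assay, with a stated time of 48 h (a lower number here means a stronger inhibitor, a higher number a weaker inhibitor), compound 1 gives the highest number of the three. Compound 2 lies nearest, a 1.9-fold lower number from compound 1 to compound 2 (0.28 log units; within the scatter), and compound 3 furthest, a 15-fold lower number from compound 1 to compound 3 (1.18 log units; beyond the scatter). Compound 4 `O=c1c2ccccc2[se]n1-c1nnc(-c2ccc(Cl)cc2)s1` differs from compound 1 by 4-chlorophenyl in place of 2-bromophenyl on an aromatic carbon. Among the compounds with values here, no measured step exchanges one halogen-bearing phenyl for another; the two steps from compound 1 change the group on the same ring carbon, one within the scatter and one large, so the expected step of a 2.0-fold lower number from compound 1 to compound 4 (0.30 log units; within the scatter) is a small lowering, with a wide range. Compound 4 is estimated at 30000 nM (range 8000 nM to 90000 nM).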

Compound 4, half-maximal inhibitory concentration: 19500 nM
For compound 4 the middle estimate is 1.5-fold (0.19 log units) above the measured one; low and high end bracket the measured number.
By their numbers in this assay, from the lowest: compound 3; then compounds 4, 2 and 1 (each within the scatter of the next, the first and the last beyond it).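

In this assay, within the data shown here, the step from 2-bromophenyl to 4-chlorophenyl (a 3.0-fold lower number from compound 1 to compound 4 (0.48 log units; beyond the scatter)) shows that the number at this position also moves beyond the scatter when one halogen-bearing phenyl replaces another, which the earlier steps, all changes on the same ring carbon, could not show. The halogen and its place on the phenyl change together in this step, so their contributions cannot be separated. Nothing measured here accounts for the step.

Which of the two changes carries the step stays open. So does how a phenyl bearing an amine or a carboxylic acid would read in this assay.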